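A few compounds are considered here, and "the series" means these few. Any claim that something is new, unique, unknown or untested is made for them only; others in the source may bear on it.

Measured compounds:
compound 1 `CCCOC(=O)/C=C/c1ccc(OS(=O)(=O)c2ccc(Cl)cc2)c(OC)c1` — 150000 nM
compound 2 `CCCCS(=O)(=O)Oc1ccc(/C=C/C(=O)OC)cc1OC` — 208000 nM
compound 3 `CCCCS(=O)(=O)Oc1ccc(/C=C/C(=O)Nc2ccccc2I)cc1OC` — 24500 nM

In a toxicity assay on L02 cells (Homo sapiens) for cytotoxicity, read by MTT assay, with a stated time of 24 h (a higher number here means that more compound is tolerated, a lower number that less compound is tolerated), compound 1 stands second highest of the three numbers. Compound 2 is nearest to it and the two lie within the scatter of each other, so no order between them can be stated. Compound 3 lies furthest from compound 1, with a number beyond the scatter lower than that of compound 1.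

Compound 4 `CCOC(=O)/C=C/c1ccc(OS(=O)(=O)c2ccc(Cl)cc2)c(OC)c1` is not yet measured in this assay. It differs from compound 1 in one place: hydrogen in place of methyl on a saturated chain carbon, two bonds along the chain from an oxygen next to a carbonyl group. Among the measured compounds shown here, the only measured step is an 8.5-fold lower number from compound 2 to compound 3 (0.93 log units; beyond the scatter), which concerns a change at the carbonyl carbon and not the length of the ester chain. For the measured compounds named here, no measured pair speaks to the difference between compound 1 and compound 4. Going by the values given here, the change removes a single chain carbon from the ester alkyl group, and with no comparable step in hand the working assumption is a step of no size beyond the scatter, in either direction.

Compound 4 is therefore expected to give 150000 nM in this assay, with a range from 75000 nM to 300000 nM. From compound 1 this corresponds to an expected step of no change at the digits printed from compound 1 to compound 4 (within the scatter).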

Compound 4, half-maximal cytotoxic concentration: 137000 nM
Beside the measured number, compound 4's estimate is 1.1-fold (0.04 log units) above it; the range from low to high includes it.
By their numbers in this assay, from the lowest: compound 3; then compounds 4, 1 and 2 (each within the scatter of the next).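

In this assay, among the compounds shown here, the change from propyl to ethyl on the ester gives a 1.1-fold lower number from compound 1 to compound 4 (0.04 log units; within the scatter) and is the only measured step at this position, two bonds along the chain from an oxygen next to a carbonyl group. The earlier step, an 8.5-fold lower number from compound 2 to compound 3 (0.93 log units; beyond the scatter), concerned the group on the carbonyl carbon and said nothing about the ester chain, whereas this pair shows that, on the core of compound 1, hydrogen in place of methyl at this place leaves the number in this assay within the scatter. Nothing on hand offers an explanation for this result.

The compounds shown cover only propyl and ethyl on this core, so a longer chain such as hexyl, a branched isopropyl group or a free carboxylic acid in place of the ester remains open. Also open, as far as these compounds go, is whether the (2-iodophenyl)amino group of compound 3 would give a step of similar size on the core of compound 1, and whether the chain change seen here would hold on other cores.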